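Removing a Methyl From an Aromatic Oxygen: Compound 2 to 3

The source may report more compounds than this note shows. Statements on the series, on what has been measured and on what is new or still open speak of the compounds shown alone.

Compound 1, `Cc1cc(O)cc(-c2nn(CC#N)cc2-c2ccnc(-c3ccc(Oc4ccccc4)cc3)c2)c1`: 6020 nM
Compound 2, `COc1cc(C)cc(-c2nn(CC#N)cc2-c2ccnc(-c3ccc(N(C)C)cc3)c2)c1`: 9690 nM

Of the compounds shown here, two have so far been measured in a functional assay on HCC 2998 cells (Homo sapiens) for inhibition, read by sulforhodamine B assay, with a stated time of 48 h; on this read-out lower numbers stand for higher toxicity in this test and higher numbers for lower toxicity in this test. Compound 1 `Cc1cc(O)cc(-c2nn(CC#N)cc2-c2ccnc(-c3ccc(Oc4ccccc4)cc3)c2)c1` gives 6020 nM, and compound 2 `COc1cc(C)cc(-c2nn(CC#N)cc2-c2ccnc(-c3ccc(N(C)C)cc3)c2)c1` gives 9690 nM. Compound 2 thus carries the higher of the two numbers, but its gap to compound 1 lies within the usual scatter of this test, so the two cannot be told apart on these data. For the measured compounds named here, they also differ in more than one place, so no single step between them can be drawn.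

Compound 3 `Cc1cc(O)cc(-c2nn(CC#N)cc2-c2ccnc(-c3ccc(N(C)C)cc3)c2)c1` is not yet measured. It differs from compound 2 in one place: hydrogen in place of methyl on an oxygen on an aromatic ring, that is, methoxy becomes hydroxy and 3-methoxy-5-methylphenyl becomes 3-hydroxy-5-methylphenyl. Compound 1 also carries the hydroxy form, but alongside a different partner group, so it offers no clean comparison. Going by the values given here, with no measured step of this kind available, the expectation is a small change in this assay, most likely toward a somewhat lower number, and possibly none beyond the scatter. Compound 3 is therefore estimated at 7000 nM in this assay, with a range from 2500 nM to 20000 nM. The implied step, a 1.4-fold lower number from compound 2 to compound 3 (0.14 log units; within the scatter), is an expectation rather than a measurement.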

Compound 3, concentration lethal to 50% of the cells: 37200 nM
Beside the measured number, compound 3's estimate is 5.3-fold (0.73 log units) below it; measured number above the stated range.
By their numbers in this assay, from the lowest: compounds 1 and 2 (each within the scatter of the next); then compound 3.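

In this assay, for the compounds shown here, hydrogen in place of methyl on an oxygen on an aromatic ring gives a 3.8-fold higher number from compound 2 to compound 3 (0.58 log units; beyond the scatter), the first measured one-place step at this position, and it shows that losing a single carbon there is enough to move the number beyond the scatter. Compound 3 also makes a clean comparison possible at the other end of the molecule: with the hydroxy form held constant, dimethylamino in place of phenoxy on an aromatic carbon gives a 6.2-fold higher number from compound 1 to compound 3 (0.79 log units; beyond the scatter). Although compound 1 and compound 2 could not be told apart, each of these two single changes has a measurable effect, and both steps toward compound 3 point to lower toxicity in this test.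

On these data alone, whether an ethyl group or a longer chain on that oxygen, or an amine in place of the hydroxy group, would shift the number in the same way remains open, as does whether the dimethylamino and phenoxy groups would differ as much alongside methoxy. Nothing available here bears on the reason for either step.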